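Methyl on the Four-Membered Ring: Does Clearance Move?

The compounds below may be only part of what the source reports. "The series", "measured", "known", "first", "only" and "open" are said of these compounds alone.

Compound 1 `O[C@H](c1ccccn1)[C@]1(c2ccc(C(F)(F)F)cc2)C[C@H](O)C1`: 50 mL/min/kg
Compound 2 `C[C@]1(O)C[C@@](c2cc(C(F)(F)F)ccn2)([C@H](O)c2ccccn2)C1`: 33.3 mL/min/kg
Compound 3 `O[C@H](c1ccccn1)[C@]1(c2cc(C(F)(F)F)ccn2)C[C@@H](O)C1`: 33.3 mL/min/kg

Three compounds have been run in an ADME assay on liver for metabolic stability, with Liver microsome (Homo sapiens) as the target, read by LC-MS, using microsomes, with a stated time of 5 h; on this read-out higher numbers stand for fast clearance and lower numbers for slow clearance. In this assay compound 1 gives 50 mL/min/kg, compound 2 gives 33.3 mL/min/kg and compound 3 gives 33.3 mL/min/kg. The three numbers lie close together; the gaps between compound 1 and either of the other two fall within the usual scatter, so no order among them can be read from these values.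

Compound 3 and compound 2 differ in one place: methyl in place of hydrogen on a saturated ring carbon. The step in this assay, no change at the digits printed from compound 3 to compound 2 (within the scatter), is the clearest information available on what this change does.

Compound 4 `C[C@]1(O)C[C@](c2ccc(C(F)(F)F)cc2)([C@H](O)c2ccccn2)C1` has not yet been measured. It differs from compound 1 by the same kind of change: methyl in place of hydrogen on a saturated ring carbon. The two place descriptions agree word for word. Compound 1 and compound 3 have different cores, and the difference between the two cores is not broken down here.

The expectation for compound 4 rests on a single observed step. Because the step of no change at the digits printed from compound 3 to compound 2 (within the scatter) stayed within the scatter, the step of a 1.1-fold lower number from compound 1 to compound 4 (0.05 log units; within the scatter) is expected to be small as well. Within the data shown here, compound 4 is therefore estimated to give 45 mL/min/kg in this assay, with a likely range from 25 mL/min/kg to 80 mL/min/kg, and with only one prior example this estimate is held loosely.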

Compound 4, clearance: 33.3 mL/min/kg
The estimate for compound 4 lay 1.4-fold (0.13 log units) above the measured number; measured number inside the range.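

On the core of compound 1, methyl in place of hydrogen on a saturated ring carbon of the four-membered ring gives, in this assay, a 1.5-fold lower number from compound 1 to compound 4 (0.18 log units; within the scatter), a step no larger than repeated measurements of one compound can produce. The same change can now be set side by side on two cores, and the two steps do not differ: the same change on two cores in this assay, no change at the digits printed (within the scatter) from compound 3 to compound 2 and a 1.5-fold lower number (0.18 log units; within the scatter) from compound 1 to compound 4, 1.5-fold (0.18 log units) apart, within the scatter of two such steps. This shows that, in these two pairs, the methyl carried from one core to the other left clearance within the scatter both times, so the earlier step was a fair guide to the size of the new one; it does not show that the methyl has no effect at all, since a small real effect could hide inside the scatter, and two pairs in one assay cannot establish a rule for the whole series.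

The compounds shown leave open what a group other than methyl on that same ring carbon would do, such as an ethyl group, a longer chain, a fluorine or an amine. They also leave open whether the methyl step stays this small on a core that carries a nitrile in place of the trifluoromethyl group.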